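A few compounds are considered here, and "the series" means these few. Any claim that something is new, unique, unknown or untested is made for them only; others in the source may bear on it.

Measured compounds:
- compound 1, `CCCc1nc(-c2ccccc2)c(CNCCN2CCN(c3cccc(C(F)(F)F)c3)CC2)o1`: 1940 nM
- compound 2, `CCCc1nc(-c2ccccc2)c(CNCCCN2CCN(c3cccc(Cl)c3)CC2)o1`: 1750 nM

For the measured compounds named here, the two compounds measured so far share the same core and differ in the group on the piperazine-bound phenyl ring and in the length of the chain between the amine and the piperazine. In an assay on HEK293 cells for inhibition of Voltage-dependent T-type calcium channel subunit alpha-1G (Homo sapiens), read by patch clamp (on this read-out higher numbers stand for weaker inhibition and lower numbers for stronger inhibition), compound 1 gives 1940 nM, the higher of the two numbers, while in this assay compound 2 gives 1750 nM; the gap between them lies within the usual scatter of repeated measurements, so the two cannot be ordered on these data.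

The step of interest leads from compound 1 to compound 3, `CCCc1nc(-c2ccccc2)c(CNCCN2CCN(c3ccccc3)CC2)o1`, which has not been measured in this assay. The change is hydrogen in place of trifluoromethyl on an aromatic carbon. Going by the values given here, no measured pair shows this change, so its effect has to be guessed. Among the compounds with values here, with only two values known, both close together, the account can say no more than that the trifluoromethyl group is removed without replacement.

Compound 3 is expected to give a somewhat higher number in this assay, estimated at 4000 nM, with a range from 1500 nM to 12000 nM. The expected step of a 2.1-fold higher number from compound 1 to compound 3 (0.31 log units; beyond the scatter) is modest and points toward weaker inhibition, but it could well fall inside the scatter.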

Compound 3, half-maximal inhibitory concentration: 10300 nM
Beside the measured number, compound 3's estimate is 2.6-fold (0.41 log units) below it; the measured number falls inside the stated range.
By their numbers in this assay, from the lowest: compounds 2 and 1 (each within the scatter of the next); then compound 3.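

In this assay, for the compounds shown here, putting hydrogen in place of trifluoromethyl gives a 5.3-fold higher number from compound 1 to compound 3 (0.73 log units; beyond the scatter), a step beyond the scatter and the first single change whose size can be read. It shows that this place on the aromatic ring is not indifferent: the 3-(trifluoromethyl)phenyl of compound 1 goes with stronger inhibition than the plain phenyl of compound 3, something the close values of compound 1 and compound 2 could not show. Nothing measured here says what lies behind this difference.

Going by these compounds, compound 2 carries chlorine but also differs from compound 1 in chain length, so the data do not set chlorine against trifluoromethyl, and it remains open whether a chlorine, a methoxy group or a nitrile on the shorter chain of compound 1 would match trifluoromethyl or fall closer to hydrogen. Also open, on these data alone, is whether removing the group would cost as much on the longer chain of compound 2, and whether the same group at another place on the ring would give a similar number.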